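The source may hold more compounds than are shown below. What is called first, only, known or untested is meant among the compounds shown, and "the series" means these compounds.

Measured so far:
compound 1 `CC(C)n1nc(-c2cccnc2)c2ccccc2c1=O` 87%
compound 2 `O=c1c2ccccc2c(-c2cccnc2)nn1Cc1cccc(Cl)c1` 95%
compound 3 `CC(=O)OCCn1nc(-c2cccnc2)c2ccccc2c1=O` 32%

In an assay on isolated protein (Oryctolagus cuniculus) with Thromboxane-A synthase (Homo sapiens) as the target, tested at 1 uM (on this read-out higher numbers stand for more inhibition at the one concentration tested (going by the name of the read-out) and lower numbers for less inhibition), compound 3 stands lowest of the three, its nearest neighbour being compound 1 and its furthest compound 2. Compound 4 `O=C(O)Cn1nc(-c2cccnc2)c2ccccc2c1=O` is not yet measured; it differs from compound 3 by carboxy in place of acetoxymethyl on a saturated chain carbon bound to an aromatic nitrogen. Among the measured compounds shown here, the steps that bear on this position are a number 55 percentage points lower from compound 1 to compound 3 (beyond the scatter) and a number 63 percentage points lower from compound 2 to compound 3 (beyond the scatter), both large, while a number 8 percentage points higher from compound 1 to compound 2 (within the scatter) lies within the scatter. For the measured compounds named here, no measured step shows what a carboxy group does here, so the direction of the step in this assay is open; the author expects a modest rise, a number 13 percentage points higher from compound 3 to compound 4 (beyond the scatter), with wide uncertainty. Compound 4 is therefore estimated at 45%, within 10% to 80%.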

Compound 4, a percentage reported as inhibition, at one concentration (the size of the read-out at that concentration, not a potency): 13%
Compound 4: middle estimate off by 32 percentage points, on the high side; measured number inside the range.
By their numbers in this assay, from the lowest: compound 4; then compound 3; then compounds 1 and 2 (each within the scatter of the next).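

In this assay, carboxy in place of acetoxymethyl on a saturated chain carbon bound to an aromatic nitrogen gives a number 19 percentage points lower from compound 3 to compound 4 (beyond the scatter), so this change does not restore what 2-acetoxyethyl lost and instead goes further down. The gaps to the other side chains widen, with a number 74 percentage points lower from compound 1 to compound 4 (beyond the scatter) and a number 82 percentage points lower from compound 2 to compound 4 (beyond the scatter), leaving compound 4 the lowest of the set. Nothing measured here accounts for this fall. Open, on these data alone, is whether the drop follows the acid or the shorter chain: a methyl ester or primary amide on that carbon, or a longer chain ending in a carboxylic acid, would separate the two.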